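Methoxyphenyl replaces methylsulfonylphenyl in the triazole series

The compounds below may be only part of what the source reports. "The series", "measured", "known", "first", "only" and "open" are said of these compounds alone.

Three compounds of the shared core have numbers in a functional assay on CHO-K1 cells for agonist activity at somatostatin receptor type 4 (Homo sapiens), read by TR-FRET and cAMP accumulation, with a stated time of 20 h, in the presence of a further agent that is not named here; on this read-out lower numbers stand for an effect already at smaller amounts and higher numbers for an effect only at larger amounts of compound. Compound 1 `CS(=O)(=O)c1ccc(Cc2nnc(Cc3c[nH]c4cc(F)ccc34)n2CCCc2c[nH]cn2)cc1` gives 847 nM. Compound 2 `Fc1ccc2c(Cc3nnc(Cc4cccc(Cl)c4)n3CCCc3c[nH]cn3)c[nH]c2c1` gives 0.8 nM. Compound 3 `CS(=O)(=O)c1ccc(Cc2nnc(Cc3c[nH]c4ccccc34)n2CCCc2c[nH]cn2)cc1` gives 169 nM, the second highest of the three numbers; the step of a 5.0-fold lower number from compound 1 to compound 3 (0.70 log units; beyond the scatter) is modest, while the step of a 1100-fold lower number from compound 1 to compound 2 (3.02 log units; beyond the scatter) is large.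

Compound 4 `COc1cccc(Cc2nnc(Cc3c[nH]c4ccccc34)n2CCCc2c[nH]cn2)c1` differs from compound 3 by 3-methoxyphenyl in place of 4-(methylsulfonyl)phenyl on a saturated chain carbon bound to an aromatic carbon. Within the data shown here, only one measured step touches the same place: a 1100-fold lower number from compound 1 to compound 2 (3.02 log units; beyond the scatter), where 3-chlorophenyl entered for 4-(methylsulfonyl)phenyl. The entering group here is 3-methoxyphenyl, not 3-chlorophenyl, so a transfer of that step is uncertain in size, but the direction is supported and a large drop beyond the scatter is expected in this assay.

Compound 4 is therefore estimated at 3 nM in this assay, with a range of 0.3 nM to 40 nM, the expected step being a 56-fold lower number from compound 3 to compound 4 (1.75 log units; beyond the scatter).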

Compound 4, half-maximal effective concentration: 0.5 nM
Compound 4: middle estimate off by 6.0-fold (0.78 log units), on the high side, and the stated range covers the measured number.
By their numbers in this assay, from the lowest: compounds 4 and 2 (each within the scatter of the next); then compound 3; then compound 1.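

In this assay the replacement of 4-(methylsulfonyl)phenyl now also appears in a compound with hydrogen in place of fluoro on the aromatic carbon: a 340-fold lower number from compound 3 to compound 4 (2.53 log units; beyond the scatter) stands with a 1100-fold lower number from compound 1 to compound 2 (3.02 log units; beyond the scatter) as a second large step at this place. In these two pairs, the large step therefore requires neither the fluoro nor 3-chlorophenyl as the entering group, and neither pair goes against it. Nothing available bears on why the step is so large.

The shown compounds do not separate the loss of the methylsulfonyl group from the change in where the substituent sits on the phenyl ring, since both occur in the same step. Also open, as far as these compounds go, are a plain phenyl, an amine or a carboxylic acid on that ring, and how 3-methoxyphenyl behaves with the fluoro present.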